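Bromo in Place of Fluoro at the Detection Limit

This account rests on a few compounds, and the source may have more. Where it says the series, first, only, none or still open, it means among the compounds named here.

Compound 1 `Nc1nc(N)c2nc(CNc3ccc(C(=O)N[C@@H](CC(F)C(=O)O)C(=O)O)cc3F)cnc2n1`: > 100000 nM
Compound 2 `Nc1nc(N)c2nc(CNc3ccc(C(=O)N[C@@H](CC(F)C(=O)O)C(=O)O)cc3C(F)(F)F)cnc2n1`: > 100000 nM; > 100000 nM (2 entries)
Compound 3 `Cc1cc(C(=O)N[C@@H](CC(F)C(=O)O)C(=O)O)ccc1NCc1cnc2nc(N)nc(N)c2n1`: > 100000 nM; > 100000 nM (2 entries)

All three measured compounds share one core and differ only in the small group on the six-membered aromatic ring of carbon only. In a functional assay on EL4 cells (Mus musculus) for inhibition (on this read-out higher numbers stand for weaker inhibition and lower numbers for stronger inhibition), compound 1 gives > 100000 nM, which is a limit of the assay and not a number. Compound 2 returns > 100000 nM; > 100000 nM (2 entries) in this assay. Compound 3 stands at > 100000 nM; > 100000 nM (2 entries) in this assay. So compound 1 cannot be placed against the other two: every value shown sits at the limit of > 100000 nM in this assay, at which 1 of the 3 values shown sits, and no step between measured compounds can be drawn.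

Compound 4 `Nc1nc(N)c2nc(CNc3ccc(C(=O)N[C@@H](CC(F)C(=O)O)C(=O)O)cc3Br)cnc2n1` is the next member. It differs from compound 1 by bromo in place of fluoro on an aromatic carbon, ortho to a large group and meta to a large group. For the measured compounds named here, with no measured step to lean on, the expected step from compound 1 to compound 4 in this assay is a step that the limit leaves unreadable from compound 1 to compound 4, which should be read as none beyond the scatter, since compound 1 itself gives only a limit. Compound 4 is therefore expected to show 150000 nM in this assay, within 30000 nM to 1000000 nM, and most likely only a limit is reported.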

Compound 4, half-maximal inhibitory concentration: > 100000 nM
Compound 4: only a limit was reported; the forecaster's own chance of this, stated with the estimate: 80%; the middle value lies beyond the limit too.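

In this assay compound 4 gives > 100000 nM, which is a limit of the assay and not a number. Compound 1 also gives only a limit, so no step between compound 1 and compound 4 can be read: the limit of > 100000 nM in this assay, at which 2 of the 4 values shown sit.

The compounds shown leave open whether any of these groups on the aromatic ring changes inhibition in this assay.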